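This account rests on a few compounds, and the source may have more. Where it says the series, first, only, none or still open, it means among the compounds named here.

Compound 3 `COc1ccccc1NC(=O)C1c2ccccc2CCN1C(=O)c1ccc(Cl)cc1` gives 1590 nM in a functional assay on NUGC-3 cells (Homo sapiens) for inhibition, read by sulforhodamine B assay, with a stated time of 48 h (on this read-out lower numbers stand for stronger inhibition of growth and higher numbers for weaker inhibition of growth), the lowest of the two numbers measured here. Compound 1 `O=C(Nc1ccc(C(F)(F)F)cc1)C1c2ccccc2CCN1C(=O)c1ccc(Cl)cc1` gives 4200 nM in this assay. Compound 2 `COc1ccccc1NC(=O)C1NCCc2ccccc21` is reported only at > 10000 nM, which is a limit of this assay and not a number. Two single-point steps lead to compound 3. Along the step from compound 1 the aryl group on the amide-type nitrogen changes, and the outcome is a 2.6-fold lower number from compound 1 to compound 3 (0.42 log units; beyond the scatter). Along the step from compound 2 the ring nitrogen is acylated, with an at least 6.2-fold lower number from compound 2 to compound 3 (0.79 log units; beyond the scatter).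

Compound 4 `O=C(Nc1ccc(O)cc1)C1c2ccccc2CCN1C(=O)c1ccc(Cl)cc1` differs from compound 3 in 4-hydroxyphenyl in place of 2-methoxyphenyl on an amide-type nitrogen. Among the measured compounds shown here, of the measured steps only the one from compound 1 to compound 3 touches the same place, and it moved the number by a modest amount. Since that step swapped one aryl group for another at this position and gave a 2.6-fold lower number from compound 1 to compound 3 (0.42 log units; beyond the scatter), a change of comparable size in either direction is plausible, with no strong reason to expect gain. Compound 4 is therefore expected to land near compound 3, at an estimated 2500 nM, between 800 nM and 8000 nM. The step of a 1.6-fold higher number from compound 3 to compound 4 (0.20 log units; within the scatter) is thus expected to be small and possibly within the scatter.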

Compound 4, concentration for 50% growth inhibition: > 10000 nM
Compound 4 ended at the assay's limit; the forecaster's own chance of this, stated with the estimate: 15%; at least 4.0-fold (0.60 log units) between middle value and limit.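

Compound 4 is reported at > 10000 nM in this assay, which is a limit of the assay and not a number. The aryl group on the amide-type nitrogen had moved the number only modestly between the two earlier compounds, but this position can matter more than that pair showed: 4-hydroxyphenyl in place of 2-methoxyphenyl gives an at least 6.2-fold higher number from compound 3 to compound 4 (0.79 log units; beyond the scatter), and hydroxy in place of trifluoromethyl on an aromatic carbon gives an at least 2.3-fold higher number from compound 1 to compound 4 (0.37 log units; beyond the scatter). With the acylated ring nitrogen kept, a change at this position alone is thus enough to reach the limit, and both steps give only a smallest size since one end of each is not a number: the limit of > 10000 nM in this assay, at which 2 of the 4 values shown sit.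

The step from compound 3 to compound 4 changes both the oxygen group, from methoxy to hydroxy, and where it stands in the aryl name, and the compounds shown do not separate these two changes. On these data alone, whether an amine or a carboxylic acid in place of the hydroxy group of compound 4 would give a measurable number also stays open.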